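Chloro for methoxy on the benzyl arm: one step

The source may report more compounds than this note shows. Statements on the series, on what has been measured and on what is new or still open speak of the compounds shown alone.

Measured compounds:
compound 1 `COc1ccc(CN(C)CCCn2c(=O)oc3ccccc32)cc1`: 83 nM
compound 2 `Cc1ccc(CN(C)CCCCn2c(=O)oc3ccccc32)c(C)c1`: 239 nM

In an assay on membranes from liver for displacement of a labelled ligand from Sigma non-opioid intracellular receptor 1 (Rattus norvegicus), read by scintillation counting (a lower number here means a stronger inhibitor, a higher number a weaker inhibitor), compound 1 gives 83 nM, the lowest of the two numbers; compound 2 gives 239 nM, a higher number that lies beyond the scatter. Compound 3 `CN(CCCn1c(=O)oc2ccccc21)Cc1ccc(Cl)cc1` is not yet measured. It differs from compound 1 by chloro in place of methoxy on an aromatic carbon. Among the compounds with values here, no pair of measured compounds isolates this kind of change, so the expectation for compound 3 rests on compound 1 alone. The expected step of a 1.4-fold lower number from compound 1 to compound 3 (0.14 log units; within the scatter) is small, within the scatter or a slight move toward a lower number. Compound 3 is expected to give 60 nM, with a range from 20 nM to 180 nM.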

Compound 3, inhibition constant: 1150 nM
Estimate against measurement, compound 3: 19-fold (1.28 log units) below; measured number above the stated range.
By their numbers in this assay, from the lowest: compound 1; then compound 2; then compound 3.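

In this assay the 4-methoxyphenyl to 4-chlorophenyl change gives a 14-fold higher number from compound 1 to compound 3 (1.14 log units; beyond the scatter) and is the only single-place step shown in the series. This position on the aromatic ring of the benzyl arm is therefore sensitive to its substituent: methoxy and chloro are not interchangeable here, and the lower number stays with methoxy. Still open, on these data alone, is whether hydroxy, fluoro or plain hydrogen at this place would read closer to compound 1 or to compound 3, and whether the same change holds on a butyl chain. No measurement at hand accounts for the loss.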